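Hydroxy to methoxy on the core of compound 1

A few compounds are considered here, and "the series" means these few. Any claim that something is new, unique, unknown or untested is made for them only; others in the source may bear on it.

Measured so far in a functional assay on the whole organism for inhibition, with Digitaria ciliaris as the target, with a stated time of 72 h, tested at 10 mg/L; a higher number here means more inhibition of growth at the concentration tested, a lower number less inhibition of growth:
compound 1 `Cc1cc(O)nc(NC(=S)NC(=O)c2c(-c3ccc(Cl)cc3Cl)noc2C)n1` gives -6.24%
compound 2 `Cc1onc(-c2ccc(Cl)cc2Cl)c1C(=O)/N=c1/nc2nc(Cl)cc(C)n2s1` gives 32.8%
compound 3 `CSc1cc(C)nc2n/c(=N/C(=O)c3c(-c4ccc(Cl)cc4Cl)noc3C)sn12` gives 26.8%

Compound 1 stands lowest of the three numbers. Its nearest neighbour is compound 3, whose number lies higher, beyond the scatter; compound 2 lies higher still, also beyond the scatter. For the measured compounds named here, compound 2 and compound 3 share a different ring system at the acyl imine end, so no pair of measured compounds differs in one place, and no single step is available to read.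

Compound 4 `COc1cc(C)nc(NC(=S)NC(=O)c2c(-c3ccc(Cl)cc3Cl)noc2C)n1` is the next entry. It differs from compound 1 by methyl in place of hydrogen on an oxygen on an aromatic ring, read one bond further out as hydroxy to methoxy. Nothing measured covers this change. The step of a number 11.2 percentage points higher from compound 1 to compound 4 (beyond the scatter) is expected to be small, most likely none beyond the scatter, with a slight lean upward. For compound 4 the estimate is 5%, within a range from -15% to 30%.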

Compound 4, percent growth inhibition at one concentration: 30.2%
Compound 4: the middle estimate sits 25.2 percentage points below what was measured; the whole stated range lies below it.
By their numbers in this assay, from the lowest: compound 1; then compounds 3, 4 and 2 (each within the scatter of the next).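

In this assay, for the compounds shown here, methyl in place of hydrogen on an oxygen on an aromatic ring gives the first single change that can be read, and the step is a number 36.4 percentage points higher from compound 1 to compound 4 (beyond the scatter) and is large. This position on the core of compound 1 is therefore not indifferent to a change of one heavy atom: hydroxy gives no positive inhibition, with compound 1 at -6.24% in this read-out, whereas methoxy gives clear inhibition, with compound 4 at 30.2% at the same concentration. Nothing at hand bears on why the step is so large.

Only hydroxy and methoxy are shown at this position, so it stays open whether a longer chain such as ethoxy or an amine would hold the higher value. From the compounds shown here alone, it also stays open whether the same change would give a similar step on the core shared by compound 2 and compound 3.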